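The compounds below may be only part of what the source reports. "The series", "measured", "known", "first", "only" and "open" are said of these compounds alone.

Compound 1 `O=C(Nc1ccc(C(F)(F)F)cc1)c1cc(Br)ccc1O` carries a free hydroxyl on the core, and in an ADME assay on MONO-MAC-6 cells (Homo sapiens) for cytotoxicity, read by MTT assay, with a stated time of 16 h (a lower number here means a stronger inhibitor, a higher number a weaker inhibitor), compound 1 gives 7600 nM. Compound 2 `O=C(NCCCCl)Oc1ccc(Br)cc1C(=O)Nc1ccc(C(F)(F)F)cc1` bears a (3-chloropropyl)carbamoyl on that oxygen; in this assay compound 2 gives 5700 nM, the step being a 1.3-fold lower number from compound 1 to compound 2 (0.12 log units; within the scatter). Among the compounds with values here, of the two numbers so far compound 2 has the lower, but the gap to compound 1 lies within the scatter, so no order between them can be claimed. Compound 3 `O=C(NCCCCl)Oc1ccc(Br)cc1C(=O)Nc1ccc(C(=O)c2ccccc2)cc1` differs from compound 2 by benzoyl in place of trifluoromethyl on an aromatic carbon. Within the data shown here, no measured step touches this part of the molecule: the only one, from compound 1 to compound 2, altered the oxygen on the aromatic ring and stayed within the scatter. Nothing in the series therefore points to a move in either direction, and the step of a 1.0-fold lower number from compound 2 to compound 3 (0.02 log units; within the scatter) is expected to stay within the scatter. For compound 3 the estimate in this assay is 5500 nM, with a range from 2000 nM to 15000 nM.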

Compound 3, half-maximal inhibitory concentration: 12600 nM
Estimate against measurement, compound 3: 2.3-fold (0.36 log units) below; measured number inside the range.
By their numbers in this assay, from the lowest: compounds 2, 1 and 3 (each within the scatter of the next, the first and the last beyond it).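

In this assay, within the data shown here, the aromatic carbon carrying trifluoromethyl is the first place where a single change moves the number beyond the scatter: benzoyl in place of trifluoromethyl gives a 2.2-fold higher number from compound 2 to compound 3 (0.34 log units; beyond the scatter), a modest step towards a weaker inhibitor. The earlier change on the oxygen on the aromatic ring, a 1.3-fold lower number from compound 1 to compound 2 (0.12 log units; within the scatter), showed no such separation, so this position responds where that one did not. Nothing available here accounts for the step.

A phenyl or an acetyl on the same aromatic carbon would separate the contribution of the added ring from that of the carbonyl. Also open, on these data alone, are how an amine or a carboxylic acid would read at this position, and whether the step holds on the free hydroxyl core of compound 1.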